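Chlorine Returns in a New Phenyl Arrangement

A few compounds are considered here, and "the series" means these few. Any claim that something is new, unique, unknown or untested is made for them only; others in the source may bear on it.

Measured compounds:
compound 1 `Cc1c(OCCCCOc2ccc(C(=O)O)cc2Cl)ccc(C(=O)CC2CCCC2)c1O` gives 21% in an ADME assay (liver) for metabolic stability, with Liver microsome (Rattus norvegicus) as the target, read by LC-MS, using microsomes and NADPH, with stated times of 5 min and 60 min, tested at 4 uM; a higher number here means that more of the compound is left, a lower number that less of the compound is left
compound 2 `Cc1c(OCCCCOc2ccc(C(=O)O)cc2F)ccc(C(=O)CC2CCCC2)c1O` gives 66% in this assay

Compound 2 stands highest of the two numbers in this assay; its nearest neighbour is compound 1, lower by a number 45 percentage points higher from compound 1 to compound 2 (beyond the scatter). Compound 3 `Cc1c(OCCCCOc2ccc(C(=O)O)c(Cl)c2)ccc(C(=O)CC2CCCC2)c1O` is not yet measured. It differs from compound 2 by 4-carboxy-3-chlorophenyl in place of 4-carboxy-2-fluorophenyl on an oxygen on a saturated carbon. Among the compounds with values here, the only measured step that bears on this change is a number 45 percentage points higher from compound 1 to compound 2 (beyond the scatter), and it was large; compound 3 reverses that swap of halogen, yet as 4-carboxy-3-chlorophenyl, not the group of compound 1. A downward step in this assay is therefore expected, with uncertainty, of about a number 31 percentage points lower from compound 2 to compound 3 (beyond the scatter). For compound 3 the estimate is 35%, from 15% to 60%.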

Compound 3, percent of the compound remaining: 67%
The estimate for compound 3 lay 32 percentage points below the measured number, outside the stated range (above it).
By their numbers in this assay, from the lowest: compound 1; then compounds 2 and 3 (each within the scatter of the next).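

In this assay, chlorine on this ring does not by itself go with a low number: 4-carboxy-3-chlorophenyl in place of 4-carboxy-2-chlorophenyl gives a number 46 percentage points higher from compound 1 to compound 3 (beyond the scatter). With 4-carboxy-3-chlorophenyl in place of 4-carboxy-2-fluorophenyl, the result is a number 1 percentage points higher from compound 2 to compound 3 (within the scatter), so the two groups cannot be told apart here. Nothing at hand explains why the place of the chlorine matters so much. The compounds shown leave open how 4-carboxy-3-fluorophenyl, or trifluoromethyl in place of the halogen, would read in this assay.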